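A trifluoromethoxy group added to compound 3

This account rests on a few compounds, and the source may have more. Where it says the series, first, only, none or still open, it means among the compounds named here.

In a functional assay on COLO 205 cells (Homo sapiens) for inhibition, read by sulforhodamine B assay (a lower number here means a stronger inhibitor of growth, a higher number a weaker inhibitor of growth), compound 3 `Cc1ccc2[nH]c(-c3ccc(-c4ccc(-c5ccccc5)cc4)cc3)nc2c1` gives 2560 nM, level with compound 1 `COc1ccc(-c2ccc(-c3ccc(-c4nc5cc(C)ccc5[nH]4)cc3)cc2)cc1OC` at 2320 nM and far lower than compound 2 `FC(F)(F)Oc1ccc(-c2ccc(-c3ccc(-c4nc5ccccc5[nH]4)cc3)cc2)cc1` at 100000 nM. Compound 4 `Cc1ccc2[nH]c(-c3ccc(-c4ccc(-c5ccc(OC(F)(F)F)cc5)cc4)cc3)nc2c1` has not yet been measured. It is compound 3 with trifluoromethoxy in place of hydrogen on an aromatic carbon, para to a large group: trifluoromethoxy in place of hydrogen on an aromatic carbon.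

Going by the values given here, the one measured step that bears on this change, a 1.1-fold higher number from compound 1 to compound 3 (0.04 log units; within the scatter), puts phenyl in place of 3,4-dimethoxyphenyl. That step stays within the scatter, so it gives no sign that a substituent at this end must shift the number. Compound 2 also carries trifluoromethoxy and gives 100000 nM, however, so a rise beyond the scatter is expected, though its size is uncertain. The expected change is a 2.3-fold higher number from compound 3 to compound 4 (0.37 log units; beyond the scatter). For compound 4 the estimated value is 6000 nM, with an expected range from 1500 nM to 50000 nM.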

Compound 4, concentration for 50% growth inhibition: 30600 nM
Beside the measured number, compound 4's estimate is 5.1-fold (0.71 log units) below it, within the range that was stated.
By their numbers in this assay, from the lowest: compounds 1 and 3 (each within the scatter of the next); then compound 4; then compound 2.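

In this assay, trifluoromethoxy on the end ring, para to a large group, gives a 12-fold higher number from compound 3 to compound 4 (1.08 log units; beyond the scatter) and a similar loss against the dimethoxy analogue, a 13-fold higher number from compound 1 to compound 4 (1.12 log units; beyond the scatter), so this end of the molecule is not indifferent to what it carries, as the earlier swap of 3,4-dimethoxyphenyl for phenyl might have suggested. With trifluoromethoxy in place, the methyl on the core still counts, since adding it gives a 3.3-fold lower number from compound 2 to compound 4 (0.51 log units; beyond the scatter), though that recovers only a modest part of the loss. Nothing available here explains why this group weakens growth inhibition when the two methoxy groups do not.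

Going by these compounds, how an amine or a carboxylic acid would read at this same place remains open. So does whether a single methoxy or a lone fluorine would follow compound 3 or compound 4.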